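Oxidation state and ring substituents on a GIPR agonist

The source may report more compounds than this note shows. Statements on the series, on what has been measured and on what is new or still open speak of the compounds shown alone.

This account follows two measured compounds and one not yet measured. Compound 1 `CSc1ccc(N2CCc3c(OC4CCN(C(=O)OC(C)C)CC4)ncnc32)cc1F` gives 121% in a functional assay on CHO-K1 cells with Glucose-dependent insulinotropic receptor (Homo sapiens) as the target, read by a luciferase reporter, with a stated time of 5 h (on this read-out lower numbers stand for smaller maximal responses and higher numbers for larger maximal responses), while compound 2 `CC(C)OC(=O)N1CCC(Oc2ncnc3c2CCN3c2ccc([S@@+](C)[O-])c(F)c2)CC1` gives 155% in this assay. The step of a number 34 percentage points higher from compound 1 to compound 2 (beyond the scatter) is the only one recorded, and it leaves compound 2 standing highest of the two numbers, with compound 1 the nearest. Compound 3 `Cc1cc(S(C)(=O)=O)ccc1N1CCc2c(OC3CCN(C(=O)OC(C)C)CC3)ncnc21` differs from compound 2 by a group of 11 heavy atoms (8 carbon, 2 oxygen, 1 sulfur; one six-membered aromatic ring of carbon only) in place of a group of 10 heavy atoms (7 carbon, 1 oxygen, 1 fluorine, 1 sulfur; one six-membered aromatic ring of carbon only), on a nitrogen on an aromatic ring in a ring. For the measured compounds named here, the step from compound 1 to compound 2 touched the same ring, through an added oxygen on sulfur, and was large and upward; no measured step covers the sulfinyl-to-sulfonyl change or the swap of fluorine for methyl on that ring. The expectation is therefore a retained high response without a firm direction, so compound 3 is expected to give 140%, within 100% to 180%, an estimated step of a number 15 percentage points lower from compound 2 to compound 3 (beyond the scatter).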

Compound 3, largest response reached (reported as percent of maximum), in percent of the reference or control that the assay uses: 80%
For compound 3 the middle estimate is 60 percentage points above the measured one; the measured number lies below the stated range.
By their numbers in this assay, from the lowest: compound 3; then compound 1; then compound 2.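

On a nitrogen on an aromatic ring in a ring, the high response in this assay does not survive every sulfur-bearing aryl group: entry of 2-methyl-4-(methylsulfonyl)phenyl gives a number 75 percentage points lower from compound 2 to compound 3 (beyond the scatter), and the same group gives a number 41 percentage points lower from compound 1 to compound 3 (beyond the scatter). Compound 3 therefore stands lowest of the three, so the rise that came with one added oxygen on sulfur does not extend to this group, which also carries a methyl and lacks the fluorine. No measurement shown here bears on why the response falls.

The compounds shown leave open whether the methylsulfonyl group, the methyl or the loss of the fluorine accounts for the drop, as all three changes arrive together. Also open, going by these compounds, is how this position would respond to a nitrile or a primary amide on the aromatic ring instead of a sulfur group.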